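A few compounds are considered here, and "the series" means these few. Any claim that something is new, unique, unknown or untested is made for them only; others in the source may bear on it.

Among the measured compounds shown here, in a functional assay on HCT-116 cells (Homo sapiens) for antiproliferative activity, read by MTT assay, with a stated time of 48 h (on this read-out higher numbers stand for weaker inhibition and lower numbers for stronger inhibition), compound 1 (`CC(CCO)n1cnc2c(Cl)nc(F)nc21`) gives 19800 nM, the only actual number in this small set. Compound 2 (`CC(CCO)n1cnc2c(Cl)ncnc21`) reads > 50000 nM, which is a limit of the assay. Compound 3 (`CCCCC(CCO)n1cnc2c(N)ncnc21`) reads > 50000 nM, which is also a limit. Together these two readings make up (the limit of > 50000 nM in this assay, at which 2 of the 3 values shown sit), so compound 1 has just one number to stand on and no measured neighbour on either side.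

Compound 4 (`CCCCCC(CCO)n1cnc2c(Cl)nc(F)nc21`) keeps the core of compound 1 and alters only the side chain: butyl in place of hydrogen on a saturated chain carbon, two bonds along the chain from an aromatic nitrogen. Cut one bond further out, the same difference reads methyl to pentyl.

For the measured compounds named here, the one measured step is an at least 2.5-fold higher number from compound 1 to compound 2 (0.40 log units; beyond the scatter). It concerns hydrogen in place of fluoro on an aromatic carbon, not the chain carbon, so it gives a rough scale for this series but no direction for the new change. Compound 3 also has a longer chain on that carbon, but it differs from compound 1 elsewhere too, so no step can be read from it.

No step beyond the scatter is therefore expected in this assay, and the uncertainty runs both ways. The expected step is a 1.3-fold lower number from compound 1 to compound 4 (0.12 log units; within the scatter). Compound 4 is estimated at 15000 nM, with an expected range of 4000 nM to 50000 nM.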

Compound 4, half-maximal inhibitory concentration: 8660 nM
Estimate against measurement, compound 4: 1.7-fold (0.24 log units) above; low and high end bracket the measured number.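

In this assay, the saturated chain carbon two bonds along the chain from an aromatic nitrogen now has a measured step of its own: a 2.3-fold lower number from compound 1 to compound 4 (0.36 log units; beyond the scatter). Among the compounds shown here, with the core of compound 1 kept, butyl in place of hydrogen at this carbon moves the number towards stronger inhibition, a direction that the one earlier step, made on an aromatic carbon, could not give. Compound 3 also has a longer chain on that carbon and reads > 50000 nM, which is a limit of the assay, and it differs from compound 1 elsewhere too, so it neither supports nor opposes this step.

Going by these compounds, with only the methyl and pentyl forms of this chain on the core of compound 1, it remains open whether a longer chain such as octyl, or a chain ending in an amine, would extend, flatten or reverse the step. Any other steps to the compounds at the weak end cannot be read, because their readings are limits and not numbers: the limit of > 50000 nM in this assay, at which 2 of the 4 values shown sit.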